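Chloro for hydrogen on a fused dichloro core

The source may report more compounds than this note shows. Statements on the series, on what has been measured and on what is new or still open speak of the compounds shown alone.

Compound 1 `ClCc1ccccc1Cn1cnc2c(Cl)nc(Cl)nc21`: in a functional assay on HT-29 cells (Homo sapiens) for cytotoxicity, read by sulforhodamine B assay, with a stated time of 48 h (on this read-out higher numbers stand for lower toxicity in this test and lower numbers for higher toxicity in this test), compound 1 gives only a limit, > 100000 nM.
Compound 2 `ClCc1ccccc1Cn1cnc2c(Cl)ncnc21`: in this assay compound 2 gives only a limit, > 100000 nM.
Compound 3 `ClCc1ccccc1Cn1cnc2ncnc(Cl)c21`: in this assay compound 3 gives only a limit, > 100000 nM.

Compound 4 `ClCc1ccccc1Cn1cnc2nc(Cl)nc(Cl)c21` has not yet been measured in this assay. It differs from compound 3 by chloro in place of hydrogen on an aromatic carbon. The same change separates compound 2 from compound 1: chloro in place of hydrogen on an aromatic carbon. The two place descriptions read the same word for word, so the change is the same, not merely of the same kind. Its measured size, a step that the two limits leave unreadable from compound 2 to compound 1, cannot be read, since both ends of that step are limits. Compound 2 and compound 3 are built from the same atoms joined differently; the difference between the two cores is not broken down here.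

What is known of the series is summed up in the limit of > 100000 nM in this assay, at which 3 of the 3 values shown sit. No number has been obtained for any member, and the chloro-for-hydrogen step has left compound 1 where compound 2 already stood.

Compound 4 is therefore expected to return a limit again, estimated near 150000 nM. The expected range for compound 4 runs from 50000 nM to 500000 nM. The step that the limit leaves unreadable from compound 3 to compound 4 is expected to be small. This rests on (the limit of > 100000 nM in this assay, at which 3 of the 3 values shown sit), because compound 3 itself gives only a limit of > 100000 nM in this assay, and the same change made once before did not move the read-out off that limit.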

Compound 4, concentration lethal to 50% of the cells: > 100000 nM
Compound 4: only a limit was reported (the forecaster's own chance of this, stated with the estimate: 85%); the middle value lies beyond the limit too.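

Compound 3 and compound 4 both give only limits in this assay, so the step between them, chloro in place of hydrogen on an aromatic carbon, cannot be read. The series stays where it stood: the limit of > 100000 nM in this assay, at which 4 of the 4 values shown sit.

The compounds shown leave open whether any member of this series gives a readable number in this assay, and so whether this chloro-for-hydrogen change moves the read-out at all.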